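The source may hold more compounds than are shown below. What is called first, only, known or untested is meant among the compounds shown, and "the series" means these compounds.

Working notes on the series in a functional assay on PC-3 cells (Homo sapiens) for inhibition, read by MTT assay, with a stated time of 48 h; a higher number here means a weaker inhibitor, a lower number a stronger inhibitor. Among the measured compounds shown here, compound 1 `Cc1ccc(/C=C2\SC(=O)N(CC(=O)Nc3c(C)n(C)n(-c4ccccc4)c3=O)C2=O)cc1` gives 45300 nM, and compound 2 `Cc1c(NC(=O)CN2C(=O)S/C(=C\c3ccc(Br)cc3)C2=O)c(=O)n(-c2ccccc2)n1C` gives 17100 nM, the lower of the two numbers so far. The next compound is compound 3 `Cc1c(NC(=O)CN2C(=O)S/C(=C\c3ccc(Cl)cc3)C2=O)c(=O)n(-c2ccccc2)n1C`, which differs from compound 2 as follows: chloro in place of bromo on an aromatic carbon. In words, this is chloro in place of bromo on an aromatic carbon, the change from 4-bromophenyl to 4-chlorophenyl, para to a large group.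

For the measured compounds named here, only one measured step bears on this change. It is a 2.6-fold lower number from compound 1 to compound 2 (0.42 log units; beyond the scatter), a modest step beyond the scatter, made at the same aromatic carbon. Going by the values given here, no chloro compound has been measured, so the series gives no direct reading for this group, and a single step sets no trend. That step does suggest the size to expect: modest at most, with a slight rise in the number more likely than a fall. The expected change is a 1.3-fold higher number from compound 2 to compound 3 (0.11 log units; within the scatter), which may well not exceed the scatter. For compound 3 the estimated value is 22000 nM, with an expected range of 10000 nM to 45000 nM.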

Compound 3, half-maximal inhibitory concentration: 28900 nM
For compound 3 the middle estimate is 1.3-fold (0.12 log units) below the measured one; measured number inside the range.
By their numbers in this assay, from the lowest: compounds 2, 3 and 1 (each within the scatter of the next, the first and the last beyond it).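

In this assay, chloro in place of bromo on this aromatic carbon gives a 1.7-fold higher number from compound 2 to compound 3 (0.23 log units; within the scatter), and chloro in place of methyl gives a 1.6-fold lower number from compound 1 to compound 3 (0.20 log units; within the scatter), so compound 3 cannot be separated from either of the other two. Among the compounds shown here, the earlier compounds gave only one contrast at this position, a 2.6-fold lower number from compound 1 to compound 2 (0.42 log units; beyond the scatter); with a third group, that contrast remains the only one of the three steps beyond the scatter, and the chloro compound sits within the scatter of both ends, so the three groups do not yield a clear ranking beyond compound 2 and compound 1 being separated. No evidence is available to explain these numbers.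

The compounds shown leave open whether another group on this aromatic carbon, such as fluoro, methoxy, a carboxylic acid or an amine, would give a number outside the narrow span seen so far. They also leave open whether a change elsewhere on the shared core, such as a longer chain in place of one of its methyl groups, would produce a larger step than any seen at this position.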